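This account rests on a few compounds, and the source may have more. Where it says the series, first, only, none or still open, it means among the compounds named here.

Compounds measured so far:
compound 1 `COc1nn(C)c2ncnc(NS(=O)(=O)c3cccc(Cl)c3Cl)c12`, 63.1 nM in a functional assay on cells for antagonist activity at C-C chemokine receptor type 4 (Homo sapiens), read by GTPgammaS binding; on this read-out higher numbers stand for weaker inhibition and lower numbers for stronger inhibition
compound 2 `COc1nn(CCN(C)C)c2ncnc(NS(=O)(=O)c3cccc(Cl)c3Cl)c12`, 3980 nM in this assay

Compound 1 stands at the lowest of the two numbers; its nearest neighbour is compound 2, and the step of a 63-fold higher number from compound 1 to compound 2 (1.80 log units; beyond the scatter) is large. The step of interest leads from compound 1 to compound 3 `COc1nn(C)c2nc(N)nc(NS(=O)(=O)c3cccc(Cl)c3Cl)c12`, not yet measured in this assay. The change is amino in place of hydrogen on an aromatic carbon; the incoming group sits between two ring nitrogen atoms on the core that compound 1 and compound 3 share, on the fused six-membered aromatic ring. Going by the values given here, the only measured step, from compound 1 to compound 2, alters a different part of the molecule, namely the chain on the aromatic nitrogen, and therefore does not bear on this change. Among the compounds with values here, with no directly comparable step at hand, the expectation for compound 3 is a step of about a 1.3-fold lower number from compound 1 to compound 3 (0.10 log units; within the scatter), within the scatter. Compound 3 is thus estimated at 50 nM, with a range from 15 nM to 200 nM.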

Compound 3, half-maximal inhibitory concentration: 316 nM
Estimate against measurement, compound 3: 6.3-fold (0.80 log units) below; measured number outside the range, above it.
By their numbers in this assay, from the lowest: compound 1; then compound 3; then compound 2.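

At this position on the fused six-membered aromatic ring, between two ring nitrogen atoms, the core of compound 1 does not tolerate change without consequence: in this assay amino in place of hydrogen gives a 5.0-fold higher number from compound 1 to compound 3 (0.70 log units; beyond the scatter) and so moves the read-out toward weaker inhibition. This modest step is still smaller than the large one on the chain on the aromatic nitrogen, a 63-fold higher number from compound 1 to compound 2 (1.80 log units; beyond the scatter) in the same assay, so the added amino group costs less than that chain change does. Nothing available explains the loss.

From the compounds shown here alone, a single substituent says little about this position as a whole, so it remains open how methyl, chlorine or a methylamino group would read out there. Going by these compounds, it is also open whether amino would give a step of similar size on compound 2, with its longer chain.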